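From Methylsulfanyl to Selenium on the Imine Carbon

A few compounds are considered here, and "the series" means these few. Any claim that something is new, unique, unknown or untested is made for them only; others in the source may bear on it.

Compound 3 `CS/C(=N\C(=O)c1cc(-c2ccccc2)nc2ccccc12)NC(=O)c1cc(-c2ccccc2)nc2ccccc12` carries a methylsulfanyl group on a carbon with a double bond to nitrogen, flanked by two amide-type nitrogens that bear the shared core twice. Among the compounds with values here, in a functional assay on HT-29 cells (Homo sapiens) for cytotoxicity, read by MTT assay, with a stated time of 72 h (a higher number here means a weaker inhibitor of growth, a lower number a stronger inhibitor of growth), compound 3 gives 23700 nM, the second highest of the three numbers known here. Compound 1 `CS/C(=N\C(=O)c1ccco1)NC(=O)c1ccco1`, a smaller relative with the same methylsulfanyl group, gives 77100 nM in this assay. Compound 2 `O=C(/N=C(/NC(=O)c1cc(-c2ccccc2)nc2ccccc12)[Se]Cc1ccccc1)c1cc(-c2ccccc2)nc2ccccc12`, which carries a larger selenium-containing group at the same carbon, gives 6070 nM. Within the data shown here, the one measured step that touches the change ahead is a 3.9-fold higher number from compound 2 to compound 3 (0.59 log units; beyond the scatter), and it exchanged the heavier atom and the ring-bearing chain at the same time.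

Compound 4 `C[Se]/C(=N\C(=O)c1cc(-c2ccccc2)nc2ccccc12)NC(=O)c1cc(-c2ccccc2)nc2ccccc12` differs from compound 3 by a group of 2 heavy atoms (1 carbon, 1 selenium; no ring) in place of a group of 2 heavy atoms (1 carbon, 1 sulfur; no ring), on a carbon with a double bond to nitrogen. Among the measured compounds shown here, no measured pair separates the exchange of the heavier atom from the loss of the ring-bearing chain, so the step from compound 2 to compound 3 is only a rough guide. A modest move toward a lower number is expected for compound 4, namely a 2.0-fold lower number from compound 3 to compound 4 (0.30 log units; within the scatter), because a 3.9-fold higher number from compound 2 to compound 3 (0.59 log units; beyond the scatter) went the other way when the selenium-containing group was removed. Compound 4 is therefore estimated at about 12000 nM in this assay, within 4000 nM to 35000 nM.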

Compound 4, concentration for 50% growth inhibition: 460 nM
For compound 4 the middle estimate is 26-fold (1.42 log units) above the measured one, and the stated range ends above it.
By their numbers in this assay, from the lowest: compound 4; then compound 2; then compound 3; then compound 1.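

The step from compound 3 to compound 4 isolates what the earlier pair could not, since the step from compound 2 to compound 3 had exchanged the heavier atom and the ring-bearing chain together. In this assay, replacing methylsulfanyl with the group of 2 heavy atoms (1 carbon, 1 selenium), on a carbon with a double bond to nitrogen whose other neighbours are amide-type nitrogens, gives a 52-fold lower number from compound 3 to compound 4 (1.71 log units; beyond the scatter), so exchanging sulfur for selenium is enough on its own to produce a large change at this position. Keeping selenium and changing only the chain also matters, with hydrogen in place of phenyl on the saturated chain carbon bound to the selenium atom giving a 13-fold lower number from compound 2 to compound 4 (1.12 log units; beyond the scatter), which shows that the ring-bearing chain is not needed for the low number of compound 4, and nothing available here accounts for either step.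

The compounds shown leave open how a longer chain such as ethyl, or a chain ending in an amine or a carboxylic acid, would fare on the selenium atom. They also leave open whether exchanging sulfur for selenium would bring a similar step on the core of compound 1.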